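The compounds below may be only part of what the source reports. "The series", "measured", "known", "first", "only" and "open" are said of these compounds alone.

Of the compounds shown here, two built on a shared core have been measured in a functional assay on HL-60 cells (Homo sapiens), with a stated time of 4 days; a lower number here means a stronger inhibitor, a higher number a weaker inhibitor. Compound 1 `COc1ccc(CNC(=O)c2[nH]cnc2C(=O)Nc2ccc(Cl)c(Cl)c2)cc1` gives 18300 nM, and compound 2 `COC(=O)[C@@H](NC(=O)c1[nH]cnc1C(=O)Nc1ccc(Cl)c(Cl)c1)c1ccccc1` gives 6800 nM. Compound 2 therefore holds the lower number of the two, and its gap to compound 1 lies beyond the scatter, which makes it the stronger inhibitor of this pair. Compound 3 `COC(=O)[C@@H](NC(=O)c1[nH]cnc1C(=O)Nc1ccc(Cl)c(Cl)c1)C(C)C` departs from compound 2 in a single place: isopropyl in place of phenyl on a saturated chain carbon bound to an amide-type nitrogen and a carbonyl carbon, with isopropyl in place of phenyl on a saturated chain carbon bound to an amide-type nitrogen and a carbonyl carbon. Going by the values given here, no measured pair differs in one place only, so the data offer no direct guide to this change. The expectation starts from compound 2 at 6800 nM and allows for a modest rise in the number in this assay, close to the edge of the scatter, meaning a somewhat weaker inhibitor. Put as a change, the expected step is a 1.6-fold higher number from compound 2 to compound 3 (0.21 log units; within the scatter). For compound 3 the estimated value is 11000 nM, with an expected range from 4500 nM to 26000 nM.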

Compound 3, half-maximal inhibitory concentration: > 62500 nM
Compound 3: only a limit was reported; the forecaster's own chance of this, stated with the estimate: 8%; at least 5.6-fold (0.75 log units) between middle value and limit.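

Phenyl on the saturated chain carbon bound to an amide-type nitrogen and a carbonyl carbon proves far from interchangeable with isopropyl in this assay, where the change gives an at least 9.1-fold higher number from compound 2 to compound 3 (0.96 log units; beyond the scatter). Setting 1-(methoxycarbonyl)-2-methylpropyl in place of 4-methoxybenzyl on an amide-type nitrogen also leaves a weaker inhibitor, with an at least 3.4-fold higher number from compound 1 to compound 3 (0.53 log units; beyond the scatter), so among these three compounds the isopropyl-bearing compound 3 sits beyond the scatter from both aromatic compounds. For compound 3 the read-out is a limit and not a number: the limit of > 62500 nM in this assay, at which 1 of the 3 values shown sits.

The compounds shown do not separate the loss of the aromatic ring from the loss of carbon atoms at this position, so a cyclohexyl group on the same carbon would be the telling comparison with both phenyl and isopropyl. They also leave open how far the methyl ester shapes these readings, a question that a carboxylic acid or a primary amide in its place could address, and they give no cause for the drop.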